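Amide substituent changes on the shared core

This account rests on a few compounds, and the source may have more. Where it says the series, first, only, none or still open, it means among the compounds named here.

The shared core, as in compound 1 `CCn1c(C(=O)NCCCN(C)C)ccc1C(CC)(CC)c1ccc(OCCC(O)(CC)CC)c(C)c1`, carries an amide whose nitrogen substituents vary across the set. In an assay on cells for agonist activity at vitamin D3 receptor (Homo sapiens), with a stated time of 96 h (on this read-out higher numbers stand for an effect only at larger amounts of compound and lower numbers for an effect already at smaller amounts), compound 1 gives 5 nM. Compound 2 `CCn1c(C(=O)NCCN)ccc1C(CC)(CC)c1ccc(OCCC(O)(CC)CC)c(C)c1` gives 156 nM in this assay. Compound 3 `CCn1c(C(=O)N(CCC#N)CCC#N)ccc1C(CC)(CC)c1ccc(OCCC(O)(CC)CC)c(C)c1` gives only > 10000 nM in this assay, a limit rather than a number. Compound 3 thus stands at the limit of > 10000 nM in this assay, at which 1 of the 3 values shown sits. Both measured steps into it are large: an at least 2000-fold higher number from compound 1 to compound 3 (3.30 log units; beyond the scatter), and an at least 64-fold higher number from compound 2 to compound 3 (1.80 log units; beyond the scatter).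

Compound 4 `C=CCN(C)C(=O)c1ccc(C(CC)(CC)c2ccc(OCCC(O)(CC)CC)c(C)c2)n1CC` differs from compound 3 by a group of 5 heavy atoms (4 carbon, 1 nitrogen; no ring) in place of a group of 9 heavy atoms (6 carbon, 3 nitrogen; no ring), on a carbonyl carbon. The two steps above show that the bis(cyanoethyl) amide carries the weakest result of the three, so removing it is expected to bring a lower number, as the step of an at least 20-fold lower number from compound 3 to compound 4 (1.30 log units; beyond the scatter). Because compound 3 is only a limit, the size of that step is bounded on one side only. Compound 4 is expected at about 500 nM, most likely between 30 nM and 10000 nM.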

Compound 4, half-maximal effective concentration: > 10000 nM
Compound 4: a limit, no number; the forecaster's own chance of this, stated with the estimate: 30%; middle value at least 20-fold (1.30 log units) away from the limit.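

In this assay compound 4 gives > 10000 nM, which is a limit and not a number, so the step from compound 3 cannot be read. The readable steps are both large: an at least 64-fold higher number from compound 2 to compound 4 (1.80 log units; beyond the scatter) and an at least 2000-fold higher number from compound 1 to compound 4 (3.30 log units; beyond the scatter). On a carbonyl carbon, allyl(methyl)amino, with no nitrile, thus gives the same limit as the group with two nitriles, so a result at this limit does not depend on the nitriles: the limit of > 10000 nM in this assay, at which 2 of the 4 values shown sit.

Compound 3 and compound 4 lack both the amide hydrogen and a chain amine, so the compounds shown do not separate these two features. The open comparisons are a tertiary amide carrying a dimethylamino chain and a secondary amide carrying a plain propyl chain or a carboxylic acid.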